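The compounds below may be only part of what the source reports. "The series", "measured", "known", "first", "only" and "open" are said of these compounds alone.

Compound 1 `CC(C)c1csc(-c2cccc(CN(C)c3ccc4[nH]nc(C(=O)O)c4c3)c2O)n1` sits at the floor of this set. In an ADME assay on MDCK cells (Canis lupus familiaris) for permeability, in the apical to basolateral direction (on this read-out lower numbers stand for lower permeability and higher numbers for higher permeability), compound 1 gives < 0.05 10^-6 cm/s, which is a limit of the assay and not a number, the case covered by the limit of < 0.05 10^-6 cm/s in this assay, at which 1 of the 3 values shown sits. Compound 2 `Cc1csc(-c2cccc(CNc3ccc4[nH]nc(C(=O)O)c4c3)c2O)n1` gives 4.5 10^-6 cm/s in this assay. Compound 3 `CC(C)c1csc(-c2cccc(CNc3ccc4[nH]nc(C(=O)O)c4c3)c2O)n1` gives 1.5 10^-6 cm/s. The step of an at least 30-fold higher number from compound 1 to compound 3 (1.47 log units; beyond the scatter) is the largest movement seen, whereas a 3.0-fold lower number from compound 2 to compound 3 (0.48 log units; beyond the scatter) is modest. Compound 4 `CN(C)c1noc(-c2cccc(CN(C)c3ccc4[nH]nc(C(=O)O)c4c3)c2O)n1` keeps the methyl on the nitrogen that compound 1 carries and compound 3 lacks, and differs from compound 1 by 3-(dimethylamino)-1,2,4-oxadiazol-5-yl in place of 4-isopropyl-1,3-thiazol-2-yl on an aromatic carbon. Among the compounds with values here, no measured step exchanges this group, so neither step bears directly on the change, and the methyl on the nitrogen, present in compound 1 and absent in compound 3, remains in place. Only a modest shift is expected, with no direction supported by the data. Compound 4 is expected to give 0.1 10^-6 cm/s, within 0.03 10^-6 cm/s to 0.5 10^-6 cm/s. A step of an at least 2.0-fold higher number from compound 1 to compound 4 (0.30 log units; that floor lies within the scatter) is therefore expected. A limit rather than a number is about as likely as not for compound 4.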

Compound 4, apparent permeability in the MDCK assay: 3.4 10^-6 cm/s
Estimate against measurement, compound 4: 34-fold (1.53 log units) below; the whole stated range lies below it.
By their numbers in the MDCK assay, from the lowest: compound 3; then compounds 4 and 2 (each within the scatter of the next). At a limit, below all of these: compound 1.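

In the MDCK assay, with the methyl on the nitrogen kept, 3-(dimethylamino)-1,2,4-oxadiazol-5-yl in place of 4-isopropyl-1,3-thiazol-2-yl on the aromatic carbon ortho to a hydroxy group gives an at least 68-fold higher number from compound 1 to compound 4 (1.83 log units; beyond the scatter), so that methyl alone does not hold a compound at the floor. In the MDCK assay compound 1 gives < 0.05 10^-6 cm/s, a limit of the assay and not a number. The same change runs the other way in a physicochemical assay for solubility, measured as kinetic solubility, at pH 2 (on this read-out higher numbers stand for higher solubility and lower numbers for lower solubility), where compound 1 gives 175000 nM and compound 4 gives 16000 nM, an 11-fold lower number from compound 1 to compound 4 (1.04 log units; beyond the scatter).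

No pair shown separates the five-membered ring of the entering group from its dimethylamino group as the source of these steps. From the compounds shown here alone, a methoxy group or a longer amine in place of the dimethylamino group would test this, and hydrogen in place of the methyl on the nitrogen of compound 4 also remains open.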